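Replacing 4-nitrophenyl with 3,4-difluorophenyl on a shared core

The compounds below may be only part of what the source reports. "The series", "measured", "known", "first", "only" and "open" are said of these compounds alone.

In a functional assay on KB cells (Homo sapiens) for inhibition, with a stated time of 72 h (a lower number here means a stronger inhibitor, a higher number a weaker inhibitor), compound 1 `COc1ccc(S(=O)(=O)N2CCc3cccc(-c4ccc(N)cc4)c32)cc1` gives 249 nM while compound 2 `COc1ccc(S(=O)(=O)N2CCc3cccc(-c4ccco4)c32)cc1` gives 82 nM and compound 3 `COc1ccc(S(=O)(=O)N2CCc3cccc(-c4ccc([N+](=O)[O-])cc4)c32)cc1` gives 52.5 nM on the same scale. Compound 3 stands at the low end of these numbers, yet it cannot be told apart from compound 2. That gap is a 1.6-fold lower number from compound 2 to compound 3 (0.19 log units; within the scatter) and so counts as scatter. The gap to compound 1 is larger, at a 4.7-fold lower number from compound 1 to compound 3 (0.68 log units; beyond the scatter) and is a real difference.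

The next structure is compound 4 `COc1ccc(S(=O)(=O)N2CCc3cccc(-c4ccc(F)c(F)c4)c32)cc1` and the change is 3,4-difluorophenyl in place of 4-nitrophenyl on an aromatic carbon at the same place on the shared core. Among the measured compounds shown here, no measured compound carries fluorine, so no step speaks to this swap directly. The nearest guides are changes of the group at this place. Moving away from 4-aminophenyl gave a 3.0-fold lower number from compound 1 to compound 2 (0.48 log units; beyond the scatter) and also a 4.7-fold lower number from compound 1 to compound 3 (0.68 log units; beyond the scatter) as modest steps, while furan-2-yl and 4-nitrophenyl stayed level. Three compounds show a modest range and nothing larger.

The expected change is a 1.7-fold higher number from compound 3 to compound 4 (0.23 log units; within the scatter) in this assay which is an estimated small rise, probably not beyond the scatter. For compound 4 the estimate is 90 nM with an expected range from 35 nM to 230 nM as its likely span.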

Compound 4, half-maximal inhibitory concentration: 45 nM
Estimate against measurement, compound 4: 2.0-fold (0.30 log units) above, within the range that was stated.
By their numbers in this assay, from the lowest: compounds 4, 3 and 2 (each within the scatter of the next); then compound 1.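

In this assay, 3,4-difluorophenyl and 4-nitrophenyl cannot be told apart, with a 1.2-fold lower number from compound 3 to compound 4 (0.07 log units; within the scatter). The nitro group is therefore not needed for a low number at this place on the shared core, since a ring with 0 hydrogen-bond acceptors, against 2 for 4-nitrophenyl, does just as well. Compound 4 also stays level with the furan-2-yl compound, with a 1.8-fold lower number from compound 2 to compound 4 (0.26 log units; within the scatter), while a 5.5-fold lower number from compound 1 to compound 4 (0.74 log units; beyond the scatter) leaves compound 1, with its 4-aminophenyl group, as the only one of the four set apart from the rest, and nothing available explains why these three different groups sit together.

On these data alone, what remains open is whether the higher number of compound 1 belongs to the amino group alone, or whether a carboxylic acid or a hydroxyl group on the phenyl ring would raise the number in the same way. As far as these compounds go, it is equally open whether the two fluorines contribute anything at all, as a plain phenyl ring or a single fluorine would show, and whether a saturated group such as cyclohexyl would hold the number at this level.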